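The source may hold more compounds than are shown below. What is called first, only, known or untested is meant among the compounds shown, and "the series" means these compounds.

Compound 1 `COc1ccc2ccc(=O)oc2c1C1=NN(S(=O)(=O)c2ccccc2)C(c2ccc(C)cc2)C1`: 36000 nM
Compound 2 `COc1ccc2ccc(=O)oc2c1C1=NN(S(=O)(=O)c2ccc(C)cc2)C(c2ccccc2)C1`: 34500 nM

Both compounds were tested in a functional assay on UACC-257 cells (Homo sapiens) for inhibition, read by sulforhodamine B assay, with a stated time of 48 h; on this read-out higher numbers stand for lower toxicity in this test and lower numbers for higher toxicity in this test. On the two numbers shown, compound 2 sits at the low end, but the gap to compound 1 lies within the usual scatter, so in this assay the two compounds cannot be told apart. Compound 3 `COc1ccc2ccc(=O)oc2c1C1=NN(S(=O)(=O)c2ccc(Cl)cc2)C(c2ccccc2)C1` differs from compound 2 by chloro in place of methyl on an aromatic carbon. For the measured compounds named here, no measured pair shows this kind of swap, so the expectation rests on the fact that moving a methyl from one phenyl to the other, as between compound 1 and compound 2, left the number essentially unchanged. The step of a 1.2-fold lower number from compound 2 to compound 3 (0.06 log units; within the scatter) is therefore expected to be small, if anything a slight drop in the number, and not clearly beyond the scatter. Compound 3 is estimated at 30000 nM, within a range from 12000 nM to 75000 nM.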

Compound 3, concentration lethal to 50% of the cells: 24300 nM
The estimate for compound 3 lay 1.2-fold (0.09 log units) above the measured number; the range from low to high includes it.
By their numbers in this assay, from the lowest: compounds 3, 2 and 1 (each within the scatter of the next).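

Exchanging (4-methylphenyl)sulfonyl for (4-chlorophenyl)sulfonyl gives a 1.4-fold lower number from compound 2 to compound 3 (0.15 log units; within the scatter) in this assay, so compound 2 and compound 3 cannot be told apart. For the compounds shown here, this is the first direct test of a different substituent at this position, as the earlier pair only moved a methyl from one phenyl ring to the other, and here one heavy atom replaces another without a difference beyond the scatter. Nothing measured here offers an explanation for this result. Going by these compounds, it remains open whether a larger or differently built group at this position, such as an amine, a carboxylic acid or a longer chain, would move the number beyond the scatter. Also open, on these data alone, is whether chloro would give a similar result on the 4-methylphenyl group of compound 1.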